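Urea nitrogen substituent in a nitrothienyl pyrrolidine series

The source may report more compounds than this note shows. Statements on the series, on what has been measured and on what is new or still open speak of the compounds shown alone.

Measured compounds:
- compound 1 `O=C(Oc1ccccc1)N1CCC(CN(Cc2ccc(Cl)cc2)Cc2ccc([N+](=O)[O-])s2)C1`: "not determined" (no result reported) in a functional assay on HEK293 cells for agonist activity at nuclear receptor subfamily 1 group D member 1 (Homo sapiens), read by a luciferase reporter, with a stated time of 24 h; on this read-out lower numbers stand for an effect already at smaller amounts and higher numbers for an effect only at larger amounts of compound
- compound 2 `O=C(Nc1ccccc1)N1CCC(CN(Cc2ccc(Cl)cc2)Cc2ccc([N+](=O)[O-])s2)C1`: 620 nM

Among the compounds with values here, compound 2 is the only compound of the pair with a number in this assay; compound 1, the carbamate analogue, carries no result there, so compound 2 stands alone as the reference point and nothing can be said about its rank.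

Compound 3 `CCCCNC(=O)N1CCC(CN(Cc2ccc(Cl)cc2)Cc2ccc([N+](=O)[O-])s2)C1` differs from compound 2 in one place: butyl in place of phenyl on an amide-type nitrogen, the anilino group giving way to butylamino on the urea. Within the data shown here, no measured pair in this set shows what such a change does, so no step size can be read off. Trading the aromatic ring for a four-carbon chain at this position is expected to cost some potency beyond the scatter, but not a large amount, so for compound 3 an estimated step of a 2.1-fold higher number from compound 2 to compound 3 (0.32 log units; beyond the scatter) is assumed. Compound 3 is accordingly expected to give about 1300 nM in this assay, with a plausible range from 400 nM to 4500 nM.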

Compound 3, half-maximal effective concentration: 670 nM
Compound 3: middle estimate off by 1.9-fold (0.29 log units), on the high side, within the range that was stated.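

In this assay, within the data shown here, butyl in place of phenyl on the amide-type nitrogen gives a 1.1-fold higher number from compound 2 to compound 3 (0.03 log units; within the scatter), the first step that can be read at this position. Compound 2 and compound 3 therefore cannot be told apart in this assay, and a six-membered aromatic ring of carbon only on this nitrogen is not needed for a reading in this range. No measurement at hand bears on why the phenyl and butyl compounds read alike.

The step from the carbamate of compound 1 to the urea of compound 2 cannot be read, as compound 1 has no number. Also open, on these data alone, is how far this tolerance extends on the same nitrogen, for example to a methyl group, a longer chain such as octyl, or a butyl chain ending in an amine or a carboxylic acid.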